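The source may report more compounds than this note shows. Statements on the series, on what has been measured and on what is new or still open speak of the compounds shown alone.

Working notes on the series, step from compound 3 to compound 4.

In an assay on blood with Thromboxane-A synthase (Homo sapiens) as the target (a lower number here means a stronger inhibitor, a higher number a weaker inhibitor), compound 3 `O=C(O)CCC/C=C/c1c(Cc2cccnc2)ccc2c1CCC(NS(=O)(=O)c1ccc(Cl)cc1)C2` gives 1100 nM, the lowest of the two numbers shown; its nearest neighbour is compound 2 `O=C(O)CC/C=C/c1c(Cc2cccnc2)ccc2c1CCC(NS(=O)(=O)c1ccc(Cl)cc1)C2`, which in this assay gives 1400 nM. Compound 1 `O=C(O)CCc1c2c(cc(Cc3cccnc3)c1-c1ccccc1)CC(NS(=O)(=O)c1ccc(Cl)cc1)CC2` gives only a limit in this assay, > 10000 nM, and is noted as the limit of > 10000 nM in this assay, at which 1 of the 3 values shown sits. Going by the values given here, the one measured step, a 1.3-fold lower number from compound 2 to compound 3 (0.10 log units; within the scatter), is a lengthening of the chain and stays within the scatter.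

Compound 4 `O=C(O)CCC/C=C\c1c(Cc2cccnc2)ccc2c1CCC(NS(=O)(=O)c1ccc(Cl)cc1)C2` differs from compound 3 as follows: the two compounds have the same atoms and bonds; at least one stereo element is drawn with a configuration in one of them and without one in the other: 1 of 2 stereo elements differ; a double bond is drawn E in compound 3 and Z in compound 4. Among the compounds with values here, no measured step touches the geometry of the double bond, so the change from E to Z is untested here and the step of a 1.3-fold lower number from compound 2 to compound 3 (0.10 log units; within the scatter) is only loose guidance that small changes in this part of the molecule have not moved the number beyond the scatter. The expectation is therefore no step beyond the scatter, no change at the digits printed from compound 3 to compound 4 (within the scatter), with a broad range to cover an unknown effect of the Z arrangement. Compound 4 is estimated at 1100 nM, between 350 nM and 3500 nM.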

Compound 4, half-maximal inhibitory concentration: 350 nM
The estimate for compound 4 lay 3.1-fold (0.50 log units) above the measured number; the range from low to high includes it.
By their numbers in this assay, from the lowest: compound 4; then compounds 3 and 2 (each within the scatter of the next). At a limit, above all of these: compound 1.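

In this assay, going by these compounds alone, the geometry of the double bond is the first change at this position to move the number beyond the scatter, with a 3.1-fold lower number from compound 3 to compound 4 (0.50 log units; beyond the scatter) at identical atoms and bonds. The wider step of a 4.0-fold lower number from compound 2 to compound 4 (0.60 log units; beyond the scatter) carries both the 5-carboxypent-1-en-1-yl chain and the Z arrangement, and the chain change alone stayed within the scatter in a 1.3-fold lower number from compound 2 to compound 3 (0.10 log units; within the scatter) among the E compounds. One caveat applies to reading compounds 3 and 4 as a clean pair of isomers: the fact that one of compounds 3 and 4 is drawn with a defined configuration and the other without, at the place where they differ.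

Open, as far as these compounds go, is whether the Z arrangement gives a similar step on the 4-carboxybut-1-en-1-yl chain of compound 2. Also open, from the compounds shown here alone, is how a 6-carboxyhex-1-en-1-yl chain, or a saturated chain in place of the double bond, would compare with compound 4.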